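Pyridine replaces methyl-oxazole on a sulfonamide nitrogen

The source may hold more compounds than are shown below. What is called first, only, known or untested is meant among the compounds shown, and "the series" means these compounds.

Compound 2, `Cc1cc(NS(=O)(=O)c2ccc(N3C(=O)/C(=C/c4coc5ccccc5c4=O)N=C3c3ccc(Cl)cc3)cc2)no1`, carries a 5-methyl-1,2-oxazol-3-yl group on its sulfonamide nitrogen. In a functional assay on MCF7 cells (Homo sapiens) for cytotoxicity, read by sulforhodamine B assay, with a stated time of 72 h (a higher number here means a weaker inhibitor, a lower number a stronger inhibitor), compound 2 gives only a limit, > 100000 nM, and no number. Its one measured relative, compound 1, `O=C1/C(=C/c2coc3ccccc3c2=O)N=C(c2ccc(Cl)cc2)N1c1ccc(S(=O)(=O)Nc2nccs2)cc1`, bears a 1,3-thiazol-2-yl group on the same nitrogen. In this assay compound 1 likewise returns only a limit, > 100000 nM. The size of the step that the two limits leave unreadable from compound 1 to compound 2 cannot be read, because of the limit of > 100000 nM in this assay, at which 2 of the 2 values shown sit.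

The next change leads to compound 3, `O=C1/C(=C/c2coc3ccccc3c2=O)N=C(c2ccc(Cl)cc2)N1c1ccc(S(=O)(=O)Nc2ccccn2)cc1`, and reads: pyridin-2-yl in place of 5-methyl-1,2-oxazol-3-yl on a sulfonamide nitrogen. Among the measured compounds shown here, the only measured step that touches this nitrogen, a step that the two limits leave unreadable from compound 1 to compound 2, carries no readable size, so it gives no direction for the new group. With both known values resting at the limit, the result for compound 3 in this assay is expected to be a limit as well, with no movement beyond the scatter. The estimate for compound 3 is 150000 nM, expected to fall between 50000 nM and 500000 nM. The step that the limit leaves unreadable from compound 2 to compound 3 is accordingly expected to be small.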

Compound 3, half-maximal inhibitory concentration: > 100000 nM
Compound 3 ended at the assay's limit; the forecaster's own chance of this, stated with the estimate: 85%; the middle value does not contradict the limit.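

In this assay compound 3 gives > 100000 nM as a limit and not a number. The steps linking compound 1, compound 2 and compound 3 cannot be read, because all three values rest at the same limit: the limit of > 100000 nM in this assay, at which 3 of the 3 values shown sit. The compounds shown leave open whether any of these groups on the sulfonamide nitrogen changes cytotoxicity at all.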